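A Dimethyl Pair Added to the Cyclohexanol Ring

This account rests on a few compounds, and the source may have more. Where it says the series, first, only, none or still open, it means among the compounds named here.

Compounds measured so far:
Compound 1, `N#Cc1cnc(NCc2cnccc2C(F)(F)F)cc1N[C@H]1CC[C@H](O)CC1`, 6500 nM
Compound 2, `CC(C)(F)c1ncncc1CNc1cc(N[C@H]2CC[C@@H](O)CC2)c(C#N)cn1`, 32 nM
Compound 3, `CC(C)(C)Oc1ncncc1CNc1cc(N[C@H]2CC[C@@H](O)CC2)c(C#N)cn1`, 200 nM

These three compounds share a core and were tested in an assay on isolated protein for inhibition of protein kinase C delta type (Homo sapiens), read by TR-FRET, with a stated time of 2 h; on this read-out lower numbers stand for stronger inhibition and higher numbers for weaker inhibition. Compound 1 gives the highest number of the three, so it inhibits the enzyme least strongly in this assay; compound 3 sits well below it, and compound 2 lower still. Going by the values given here, the only single-point step among the measured compounds, a 6.3-fold higher number from compound 2 to compound 3 (0.80 log units; beyond the scatter), concerns a group on an aromatic carbon and not the ring carrying the hydroxyl.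

Compound 4, `CC1(C)C[C@H](Nc2cc(NCc3cnccc3C(F)(F)F)ncc2C#N)CC[C@@H]1O`, differs from compound 1 in exactly that hydroxyl-bearing ring: 4-hydroxy-3,3-dimethylcyclohexyl in place of 4-hydroxycyclohexyl on a nitrogen on an aromatic ring. Among the compounds with values here, no measured step touches this part of the molecule, so nothing in the data shows whether the two added methyl groups will help or hurt. Compound 4 is therefore expected to stay near compound 1, with a step of a 1.4-fold lower number from compound 1 to compound 4 (0.16 log units; within the scatter) carrying wide uncertainty. Compound 4 is estimated at 4500 nM, between 1000 nM and 15000 nM.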

Compound 4, half-maximal inhibitory concentration: 500 nM
Estimate against measurement, compound 4: 9.0-fold (0.95 log units) above; the whole stated range lies above it.
By their numbers in this assay, from the lowest: compound 2; then compound 3; then compound 4; then compound 1.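

In this assay, 4-hydroxy-3,3-dimethylcyclohexyl in place of 4-hydroxycyclohexyl gives a 13-fold lower number from compound 1 to compound 4 (1.11 log units; beyond the scatter), so the group on this nitrogen clearly affects the result, a point the earlier step, on an aromatic carbon, could not show. Both groups have the same counts of hydrogen-bond donors and acceptors and no net charge, so the difference does not lie in those counts, and the added dimethyl pair is the listed change. Nothing measured here explains why the number falls.

Going by these compounds, it remains open whether a single methyl group would have a similar effect, or whether an amine in place of the hydroxyl would preserve it. Also open, on these data alone, is whether the dimethyl ring would lower the number on compound 2 and compound 3, which differ from compound 1 elsewhere.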